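A Cyano Group Added to the Sulfonyl Phenyl Ring

The source may hold more compounds than are shown below. What is called first, only, known or untested is meant among the compounds shown, and "the series" means these compounds.

Of the compounds shown here, three built on one shared core have been tested in a functional assay on SMMC-7721 cells (Homo sapiens) for cytotoxicity, read by MTT assay, with a stated time of 24 h; on this read-out lower numbers stand for stronger inhibition and higher numbers for weaker inhibition. Compound 1 `O=C1/C(=C/c2ccccc2F)CN(S(=O)(=O)c2ccc(O[N+](=O)[O-])cc2)C/C1=C\c1ccccc1F` gives 6200 nM. Compound 2 `O=C1/C(=C/c2cccc(F)c2)CN(S(=O)(=O)c2ccccc2)C/C1=C\c1cccc(F)c1` gives 12900 nM. Compound 3 `O=C1/C(=C/c2ccc(F)cc2)CN(S(=O)(=O)c2ccccc2)C/C1=C\c1ccc(F)cc1` gives 9100 nM, a number that sits within the usual scatter of both compound 1 and compound 2, so none of the three can be set apart from the others. Compound 4 `N#Cc1ccc(S(=O)(=O)N2C/C(=C\c3ccc(F)cc3)C(=O)/C(=C/c3ccc(F)cc3)C2)cc1` awaits measurement. It differs from compound 3 in one place: cyano in place of hydrogen on an aromatic carbon. For the measured compounds named here, no measured pair shows what this change does, so only a modest step in this assay is expected, if anything toward a slightly lower number. The expected step is a 1.2-fold lower number from compound 3 to compound 4 (0.08 log units; within the scatter). Compound 4 is therefore estimated at 7500 nM, within a range from 3000 nM to 20000 nM.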

Compound 4, half-maximal inhibitory concentration: 15000 nM
Compound 4: the middle estimate sits 2.0-fold (0.30 log units) below what was measured; the range from low to high includes it.
By their numbers in this assay, from the lowest: compounds 1, 3, 2 and 4 (each within the scatter of the next, the first and the last beyond it).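

For the compounds shown here, this is the first pair that differs in only one place. In this assay putting cyano on the aromatic carbon of the phenylsulfonyl group gives a 1.6-fold higher number from compound 3 to compound 4 (0.22 log units; within the scatter) so this carbon accepts the added group without a change that can be told apart from ordinary assay scatter. Nothing available explains this result. As far as these compounds go, whether an amine or a carboxylic acid at this carbon would give a clearer step remains open. So does whether cyano would give a similar step on compound 2, where the fluorine sits elsewhere.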